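Working notes: aryl swap from compound 3 to compound 4

A few compounds are considered here, and "the series" means these few. Any claim that something is new, unique, unknown or untested is made for them only; others in the source may bear on it.

Measured in a functional assay on A549 cells (Homo sapiens) for cytotoxicity, read by MTT assay, with a stated time of 72 h (a higher number here means a weaker inhibitor, a lower number a stronger inhibitor), as follows
- compound 1 `O=C(N/N=C/c1ccc(F)cc1)Nc1cc2c(Nc3ccc(F)c(Cl)c3)ncnc2cc1O[C@H]1CCOC1` gives 35100 nM
- compound 2 `O=C(N/N=C/c1cccc(Cl)c1Cl)Nc1cc2c(Nc3ccc(F)c(Cl)c3)ncnc2cc1O[C@H]1CCOC1` gives 25000 nM
- compound 3 `COc1ccc(/C=N/NC(=O)Nc2cc3c(Nc4ccc(F)c(Cl)c4)ncnc3cc2O[C@H]2CCOC2)cc1` gives 33100 nM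

Compound 3 at 33100 nM stands within the scatter of both other compounds. Compound 4 `O=C(N/N=C/c1cc(Br)c(O)c(Br)c1)Nc1cc2c(Nc3ccc(F)c(Cl)c3)ncnc2cc1O[C@H]1CCOC1` carries 3,5-dibromo-4-hydroxyphenyl in place of 4-methoxyphenyl on a carbon with a double bond to nitrogen. Swaps at that place gave a 1.4-fold lower number from compound 1 to compound 2 (0.15 log units; within the scatter) and a 1.1-fold lower number from compound 1 to compound 3 (0.03 log units; within the scatter) and a 1.3-fold higher number from compound 2 to compound 3 (0.12 log units; within the scatter) and all three lie within the scatter. Among the compounds with values here, no measured compound carries bromine or a hydroxy group on that ring, so the basis is thin. No step beyond the scatter is therefore expected in this assay here. The expected step is a 1.3-fold lower number from compound 3 to compound 4 (0.12 log units; within the scatter) and it stays within the scatter. Compound 4 is estimated at 25000 nM (range 10000 nM to 50000 nM).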

Compound 4, half-maximal inhibitory concentration: 8910 nM
For compound 4 the middle estimate is 2.8-fold (0.45 log units) above the measured one, outside the stated range (below it).
By their numbers in this assay, from the lowest: compound 4; then compounds 2, 3 and 1 (each within the scatter of the next).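

In this assay the group on a carbon with a double bond to nitrogen can move the number beyond the scatter: 3,5-dibromo-4-hydroxyphenyl gives a 3.7-fold lower number from compound 3 to compound 4 (0.57 log units; beyond the scatter) and a 2.8-fold lower number from compound 2 to compound 4 (0.45 log units; beyond the scatter) and a 3.9-fold lower number from compound 1 to compound 4 (0.60 log units; beyond the scatter) while the three earlier aryl groups stayed within the scatter of one another. This position is therefore not indifferent to change in this assay though all three steps remain modest. Nothing measured here gives a cause for these steps. As far as these compounds go, compound 4 brings the bromine atoms and the hydroxy group together, and their separate shares stay open. Also open, from the compounds shown here alone, is how an amine or a carboxylic acid in place of that hydroxy group would read.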